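Swapping one azetidine substitution pattern for another

The source may hold more compounds than are shown below. What is called first, only, known or untested is meant among the compounds shown, and "the series" means these compounds.

Measured so far:
compound 1 `CC[C@H]1[C@@H](N)CN1c1c(F)cc2c(=O)c(C(=O)O)cn(C3CC3)c2c1F` — 55.9 ug/mL
compound 2 `C[C@@H]1[C@@H](N(C)C)CN1c1cc2c(cc1F)c(=O)c(C(=O)O)cn2C1CC1` — 96.3 ug/mL

In a physicochemical assay for solubility, at pH 7.4 (on this read-out lower numbers stand for lower solubility and higher numbers for higher solubility), compound 1 gives 55.9 ug/mL, the lower of the two numbers in hand. Its nearest neighbour, compound 2, gives 96.3 ug/mL in this assay; the gap between the two lies within the scatter, so no order can be read from it. Compound 3 `C[C@H]1N(c2c(F)cc3c(=O)c(C(=O)O)cn(C4CC4)c3c2F)C[C@]1(C)N` has not yet been measured. It differs from compound 1 as follows: a group of 7 heavy atoms (5 carbon, 2 nitrogen; one four-membered non-aromatic ring with 1 hetero atom) in place of a group of 7 heavy atoms (5 carbon, 2 nitrogen; one four-membered non-aromatic ring with 1 hetero atom), on an aromatic carbon. The two share every atom; only the joining differs. Going by the values given here, no measured pair shows such a rearrangement, so the expectation rests on the shared core alone. Given that compound 1 gives 55.9 ug/mL and the rearrangement adds nothing new, the step of a 1.0-fold lower number from compound 1 to compound 3 (0.01 log units; within the scatter) is expected to stay within the scatter in either direction. Compound 3 is therefore estimated at 55 ug/mL, with a range from 22 ug/mL to 140 ug/mL.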

Compound 3, solubility: 3.3 ug/mL
The estimate for compound 3 lay 17-fold (1.22 log units) above the measured number; the whole stated range lies above it.
By their numbers in this assay, from the lowest: compound 3; then compounds 1 and 2 (each within the scatter of the next).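

Rearranging the same atoms within the four-membered non-aromatic ring with 1 hetero atom, on the aromatic carbon ortho to two fluoro groups, gives a 17-fold lower number from compound 1 to compound 3 (1.23 log units; beyond the scatter) in this assay. Going by these compounds alone, the two groups match in every count of atoms, hydrogen-bond donors, acceptors and defined stereocentres, so this position responds strongly to how the atoms are joined, which compound 1 and compound 2, linked by no step, could not show. Nothing at hand gives a reason for this step.

As far as these compounds go, it remains open whether the same rearrangement gives a step of this size when a hydroxyl group replaces the amine or a propyl chain sits on that ring. From the compounds shown here alone, it also remains open whether it does so on a core without the second fluoro group.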